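Swapping Methyl for Cyclopropyl on the Shared Core

The source may hold more compounds than are shown below. What is called first, only, known or untested is meant among the compounds shown, and "the series" means these compounds.

In an assay on cells for inhibition of cytochrome P450 11B2, mitochondrial (Homo sapiens), read by HTRF, with stated times of 1 h and 3 h (on this read-out higher numbers stand for weaker inhibition and lower numbers for stronger inhibition), compound 1 `Fc1cncc(-n2ncc3cc(F)ccc32)c1` gives 456 nM, while compound 2 `Cc1nn(-c2cncc(C(C)(C)O)c2)c2ccccc12` gives 33.5 nM, the lower of the two numbers, with a gap to compound 1 that lies beyond the usual scatter. Compound 3 `CC(C)(O)c1cncc(-n2nc(C3CC3)c3ccccc32)c1` differs from compound 2 by cyclopropyl in place of methyl on an aromatic carbon. Within the data shown here, no pair of measured compounds shows a change of this kind, so its effect here is unknown. The step of a 1.1-fold lower number from compound 2 to compound 3 (0.05 log units; within the scatter) is expected to stay within the usual scatter, in no clear direction. Compound 3 is therefore expected to give about 30 nM, with a range from 10 nM to 100 nM.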

Compound 3, half-maximal inhibitory concentration: 760 nM
Estimate against measurement, compound 3: 25-fold (1.40 log units) below; the measured number lies above the stated range.
By their numbers in this assay, from the lowest: compound 2; then compounds 1 and 3 (each within the scatter of the next).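

Among these compounds, this aromatic carbon on the shared core proves far less forgiving than the earlier compounds could show: cyclopropyl in place of methyl brings a 23-fold higher number from compound 2 to compound 3 (1.36 log units; beyond the scatter) and thus a clear loss of inhibition. Exchanging one small carbon group for another at this place can therefore decide much of the inhibition seen with this core. Nothing available here accounts for the loss. The compounds shown include no ethyl, isopropyl or plain hydrogen at this carbon. Going by these compounds, whether the loss is particular to cyclopropyl or would appear with other groups remains open.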